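Removing the hydroxy from the chain on the triazole nitrogen

The source may hold more compounds than are shown below. What is called first, only, known or untested is meant among the compounds shown, and "the series" means these compounds.

Compound 3 `CCc1nn(CCO)nc1C(OC)c1cc(Cl)cc(Cl)c1` is assessed in an ADME assay on cells (Mus musculus) for cytotoxicity, read by MTT assay (a higher number here means that more compound is tolerated, a lower number that less compound is tolerated), where compound 3 gives 95100 nM. Compound 2 `CCc1nn(CCO)nc1Cc1cc(Cl)cc(Cl)c1` gives 84700 nM in this assay, and the two numbers sit together, as the step from compound 2 to compound 3 a 1.1-fold higher number from compound 2 to compound 3 (0.05 log units; within the scatter) shows. For compound 1 `N#Cc1cccc(Cn2cc(CCO)nn2)c1` the value > 100000 nM is a limit of this assay, not a number. That one value reaches (the limit of > 100000 nM in this assay, at which 1 of the 3 values shown sits).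

Compound 4 `CCc1nn(CC)nc1C(OC)c1cc(Cl)cc(Cl)c1` has not yet been measured. Compared with compound 3 it carries hydrogen in place of hydroxy on a saturated chain carbon, two bonds along the chain from an aromatic nitrogen. Within the data shown here, no measured step covers this change: the only step available in this assay, from compound 2 to compound 3, concerns a different group, and it stayed within the scatter. With nothing in the series pointing either way, no movement beyond the scatter is expected, and a number near that of compound 3 appears likely, with a fair chance that this assay again returns only a limit.

The expected step of a 1.1-fold lower number from compound 3 to compound 4 (0.02 log units; within the scatter) is therefore taken as none beyond the scatter. Compound 4 is estimated to give 90000 nM, expected to lie between 45000 nM and 180000 nM.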

Compound 4, half-maximal cytotoxic concentration: 89000 nM
Compound 4: the middle estimate sits 1.0-fold (0.00 log units) above what was measured; low and high end bracket the measured number.
By their numbers in this assay, from the lowest: compounds 2, 4 and 3 (each within the scatter of the next). At a limit, above all of these: compound 1.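

The change from 2-hydroxyethyl to ethyl, hydrogen in place of hydroxy on a saturated chain carbon, two bonds along the chain from an aromatic nitrogen, is the only step shown at this position, and in this assay it gives a 1.1-fold lower number from compound 3 to compound 4 (0.03 log units; within the scatter). Among these compounds, for this pair, then, losing the hydroxy, with its hydrogen-bond donor and acceptor, leaves the number within the scatter, so the earlier step at the other position is no longer the only one without a clear change. Among the compounds shown here, compound 1 remains the only compound at a limit, which is not a number: the limit of > 100000 nM in this assay, at which 1 of the 4 values shown sits.

As far as these compounds go, whether the same change would read alike on compound 2, without the methoxy, stays open. Also open, from the compounds shown here alone, is how an amine, a carboxylic acid or a longer chain at this position would read in this assay.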